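Para substituent variation on the shared core

The compounds below may be only part of what the source reports. "The series", "measured", "known", "first", "only" and "open" are said of these compounds alone.

The series keeps one core, seen in compound 1 `c1ccc(NN=C(c2nc3ccccc3[nH]2)c2nc3ccccc3[nH]2)cc1`, and varies the group on an aromatic carbon of the six-membered aromatic ring of carbon only, para to a large group. In a functional assay on HCT-116 cells (Homo sapiens) for cytotoxicity, read by MTT assay, with a stated time of 72 h (on this read-out lower numbers stand for stronger inhibition and higher numbers for weaker inhibition), compound 1 gives 162000 nM. Compound 2 `Cc1ccc(NN=C(c2nc3ccccc3[nH]2)c2nc3ccccc3[nH]2)cc1` carries methyl there and gives 195000 nM in this assay; compound 3 `Clc1ccc(NN=C(c2nc3ccccc3[nH]2)c2nc3ccccc3[nH]2)cc1` carries chloro and gives 201000 nM. Compound 3 has the highest of the three numbers, but the gaps are only a 1.2-fold higher number from compound 1 to compound 3 (0.09 log units; within the scatter) and a 1.0-fold higher number from compound 2 to compound 3 (0.01 log units; within the scatter), and the methyl step a 1.2-fold higher number from compound 1 to compound 2 (0.08 log units; within the scatter) is of the same size; all three lie within the scatter, so no order among them can be read.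

Compound 4 `O=[N+]([O-])c1ccc(NN=C(c2nc3ccccc3[nH]2)c2nc3ccccc3[nH]2)cc1` is the next member: nitro in place of chloro on an aromatic carbon. Among the compounds with values here, no measured step copies this change, and nothing about nitro is known. What bears on it is that every replacement so far at this position, hydrogen to methyl, hydrogen to chloro, methyl to chloro, has left this assay unmoved beyond the scatter. The expected step is therefore a 1.0-fold lower number from compound 3 to compound 4 (0.00 log units; within the scatter) in this assay, that is, none beyond the scatter. Compound 4 is accordingly estimated at 200000 nM, with a range from 100000 nM to 400000 nM.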

Compound 4, half-maximal inhibitory concentration: 11700 nM
Beside the measured number, compound 4's estimate is 17-fold (1.23 log units) above it, outside the stated range (below it).
By their numbers in this assay, from the lowest: compound 4; then compounds 1, 2 and 3 (each within the scatter of the next).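

Nitro is the first group shown to move this assay at this position on an aromatic carbon, para to a large group: nitro in place of chloro gives a 17-fold lower number from compound 3 to compound 4 (1.24 log units; beyond the scatter), nitro in place of methyl gives a 17-fold lower number from compound 2 to compound 4 (1.22 log units; beyond the scatter), and nitro in place of hydrogen gives a 14-fold lower number from compound 1 to compound 4 (1.14 log units; beyond the scatter). The earlier compounds shown here made the position look indifferent, but compound 4 shows that this holds only among hydrogen, methyl and chloro, and that the position itself can respond to the group it carries, with compound 4 the strongest of the four since all its steps lie beyond the scatter. Nothing measured here accounts for the size of these steps.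

Going by these compounds, with a single group standing apart, it remains open whether the drop belongs to nitro alone or would also appear with a nitrile, trifluoromethyl, a carboxylic acid, an amine or methoxy on the same carbon. Also open, on these data alone, is whether the lower number of compound 4 carries over to other cell lines, or reflects something particular to these cells.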